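A few compounds are considered here, and "the series" means these few. Any claim that something is new, unique, unknown or untested is made for them only; others in the source may bear on it.

Measured compounds:
- Compound 2, `CNc1cc(-c2ccc3cnn(Cc4ccc(F)cc4)c3c2)cn(C)c1=O`: 2390 nM
- Compound 3, `CCNc1cc(-c2ccc3cnn(Cc4ccc(F)cc4)c3c2)cn(C)c1=O`: 5650 nM
- Compound 1, `COc1ccc(CN2CC(c3ccc(O)cc3)c3cnc(-c4c(C)noc4C)nc32)cc1`: "not determined" (no result reported)

Compound 2 was tested in a functional assay on MV4-11 cells (Homo sapiens) for antiproliferative activity, read by luminescence and CellTiter-Glo, with a stated time of 72 h (on this read-out higher numbers stand for weaker inhibition and lower numbers for stronger inhibition), where it gives 2390 nM. Among the compounds with values here, compound 3 gives 5650 nM, and the single measured step, a 2.4-fold higher number from compound 2 to compound 3 (0.37 log units; beyond the scatter), is a modest weakening. Within the data shown here, compound 2 therefore stands with the lowest number among the two measured values, with compound 3 as its only measured neighbour, and compound 1 stands alongside without a number.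

Compound 4, `CNc1cc(-c2ccc3cnn(CC4CC4)c3c2)cn(C)c1=O`, is not yet measured. It differs from compound 2 in one place: cyclopropyl in place of 4-fluorophenyl on a saturated chain carbon bound to an aromatic nitrogen.

Among the measured compounds shown here, the only measured step changes the methyl on a nitrogen on an aromatic ring, a different place from the one altered here, so no measured step bears directly on the change from compound 2 to compound 4. The 4-fluorobenzyl of compound 2 is replaced by the smaller cyclopropylmethyl, and with nothing measured at that position the direction cannot be read from the data. The expectation is a step of uncertain direction, a 1.5-fold higher number from compound 2 to compound 4 (0.17 log units; within the scatter), with wide uncertainty. Compound 4 is expected to give about 3500 nM in this assay, estimated between 1000 nM and 15000 nM.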

Compound 4, half-maximal inhibitory concentration: 3450 nM
For compound 4 the middle estimate is 1.0-fold (0.01 log units) above the measured one; the range from low to high includes it.
By their numbers in this assay, from the lowest: compounds 2, 4 and 3 (each within the scatter of the next, the first and the last beyond it).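

Within the data shown here, this is the first step at this position, the group on the saturated chain carbon bound to an aromatic nitrogen, and in this assay the change gives a 1.4-fold higher number from compound 2 to compound 4 (0.16 log units; within the scatter) and so leaves compound 2 and compound 4 indistinguishable on this read-out. For this one pair, then, a six-membered aromatic ring carrying fluorine and a three-membered non-aromatic ring of carbon only, with 7 and 3 heavy atoms, give values that cannot be told apart, and neither the aromatic ring nor the fluorine is required to keep the number where it stands. Nothing available here explains why the two groups give such similar numbers.

Going by these compounds, two groups at one position cannot show how wide this tolerance runs, so it remains open whether a basic amine such as a piperidine, a carboxylic acid or a longer chain such as n-butyl would leave the number where it is or move it. On these data alone, it is also open whether the step seen on the other nitrogen chain, from methyl to ethyl, would look the same with cyclopropylmethyl in place of 4-fluorobenzyl.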